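The source may report more compounds than this note shows. Statements on the series, on what has been measured and on what is new or still open speak of the compounds shown alone.

Measured so far:
compound 1 `O=C(Nc1cccc(-n2cc(-c3ccncc3)c(-c3ccc(Cl)c(O)c3)n2)c1)Nc1cccc(C(F)(F)F)c1`, 2140 nM
compound 2 `COc1cc(-c2nn(-c3cccc(NC(=O)Nc4ccc(Cl)c(C(F)(F)F)c4)c3)cc2-c2ccncc2)ccc1Cl`, 1040 nM

In a functional assay on NCI/ADR-RES cells (Homo sapiens) for inhibition, read by sulforhodamine B assay, with a stated time of 48 h (a higher number here means a weaker inhibitor of growth, a lower number a stronger inhibitor of growth), compound 2 gives 1040 nM, the lower of the two numbers; compound 1 gives 2140 nM, a gap beyond the usual scatter. Compound 3 `O=C(Nc1cccc(-n2cc(-c3ccncc3)c(-c3ccc(Cl)c(O)c3)n2)c1)Nc1ccc(Cl)c(C(F)(F)F)c1` has not yet been measured. It differs from compound 2 in one place: hydrogen in place of methyl on an oxygen on an aromatic ring, that is, methoxy to hydroxy. Within the data shown here, no pair of measured compounds shows this change alone, since compound 1 differs from compound 2 elsewhere as well. A modest step in either direction, or none beyond the scatter, is expected. Compound 3 is expected at 1500 nM, between 600 nM and 4000 nM. That estimate means an expected step of a 1.4-fold higher number from compound 2 to compound 3 (0.16 log units; within the scatter).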

Compound 3, concentration for 50% growth inhibition: 844 nM
Compound 3: middle estimate off by 1.8-fold (0.25 log units), on the high side; the measured number falls inside the stated range.
By their numbers in this assay, from the lowest: compounds 3 and 2 (each within the scatter of the next); then compound 1.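

In this assay, the step from methoxy to hydroxy is a 1.2-fold lower number from compound 2 to compound 3 (0.09 log units; within the scatter), so these two groups cannot be told apart at this position. Chloro in place of hydrogen on an aromatic carbon gives a 2.5-fold lower number from compound 1 to compound 3 (0.40 log units; beyond the scatter), a modest step that the earlier compounds could not isolate. Nothing measured here explains either result.

As far as these compounds go, whether an ethoxy group or an amine at this position would fit as well remains open. So does whether the chloro step would hold with methoxy in place of hydroxy.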